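The compounds below may be only part of what the source reports. "The series", "measured", "known", "first", "only" and "open" are said of these compounds alone.

Compound 3 `CC(C)(C)c1cc(C(=O)N2CCc3ccccc32)cc(C#N)c1O` gives 31600 nM in an assay on tissue (RPTEC cells) for inhibition of solute carrier family 22 member 12 (Homo sapiens), read by scintillation counting, with stated times of 15 min and 2 h (a higher number here means a weaker inhibitor, a lower number a stronger inhibitor), the lowest of the two numbers measured here. Its nearest neighbour is compound 2 `N#Cc1cc(C(=O)N2CCc3ccccc32)cc(C#N)c1O`, which gives 83900 nM in this assay, so that the difference between them is the step of a 2.7-fold lower number from compound 2 to compound 3 (0.42 log units; beyond the scatter). Compound 1 `COc1cc(C(=O)N2CCc3ccccc32)cc(C#N)c1O` returns only a limit in this assay, > 100000 nM; this is the limit of > 100000 nM in this assay, at which 1 of the 3 values shown sits. Compound 4 `N#Cc1cc(C(=O)N2CCc3ccccc32)cc(C(F)(F)F)c1O` differs from compound 3 by trifluoromethyl in place of tert-butyl on an aromatic carbon. Going by the values given here, no measured step carries this exact exchange. Among the compounds with values here, the steps that bear on it are those that brought tert-butyl in, namely an at least 3.1-fold lower number from compound 1 to compound 3 (0.50 log units; beyond the scatter) and a 2.7-fold lower number from compound 2 to compound 3 (0.42 log units; beyond the scatter), both of which lowered the number. Removing tert-butyl in favour of trifluoromethyl is therefore expected to move the number back upward, by a step estimated at a 1.7-fold higher number from compound 3 to compound 4 (0.24 log units; within the scatter), though a result within the scatter of compound 3 cannot be ruled out. Compound 4 is thus expected to give about 55000 nM in this assay, with a likely range from 20000 nM to 150000 nM.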

Compound 4, half-maximal inhibitory concentration: > 100000 nM
Compound 4 gave a limit, no number; the forecaster's own chance of this, stated with the estimate: 25%; at least 1.8-fold (0.25 log units) between middle value and limit.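

In this assay, an at least 3.1-fold higher number from compound 3 to compound 4 (0.50 log units; beyond the scatter), so at this position, ortho to a hydroxy group, trifluoromethyl does not keep what tert-butyl gave, although the two groups have equal heavy-atom counts. With an at least 1.1-fold higher number from compound 2 to compound 4 (0.07 log units; that floor lies within the scatter), the floor of that step does not separate trifluoromethyl from cyano, and compound 3 now holds the lowest number of the series by steps beyond the scatter to all three others. The step between the two compounds that end at a limit cannot be read, and compound 4 gives only a limit here: the limit of > 100000 nM in this assay, at which 2 of the 4 values shown sit.

On these data alone, what an isopropyl or cyclopropyl group, an amine or a carboxylic acid would give at this position remains open. Also open, as far as these compounds go, is how far the true numbers of compound 1 and compound 4 lie from their limit.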